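The compounds below may be only part of what the source reports. "The series", "measured", "known", "first", "only" and "open" are said of these compounds alone.

Series notes. Compound 1 (`CCN1C(=O)CC[C@H]1C(=O)NCc1ccccc1`) stands at a limit: in an assay on isolated protein for inhibition of P2X purinoceptor 7 (Homo sapiens) (on this read-out higher numbers stand for weaker inhibition and lower numbers for stronger inhibition), compound 1 gives < 1000 nM, which is a limit of the assay and not a number. Compound 2 (`CCN1C(=O)CC[C@H]1C(=O)NCc1cccc(Cl)c1`) likewise gives < 1000 nM in this assay, again a limit. Among the compounds with values here, the single measured step, a step that the two limits leave unreadable from compound 1 to compound 2, is unreadable in size and direction, since (the limit of < 1000 nM in this assay, at which 2 of the 2 values shown sit). Compound 3 (`CCN1C(=O)CC[C@H]1C(=O)NCc1ccc(Cl)cc1`) differs from compound 1 by chloro in place of hydrogen on an aromatic carbon. The step to compound 2 bears on this change but fixes no size. The expected step, a step that the limit leaves unreadable from compound 1 to compound 3, is estimated to stay within the scatter. Compound 3 is estimated at 300 nM, between 30 nM and 1500 nM, and most likely comes back as a limit.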

Compound 3, half-maximal inhibitory concentration: 631 nM
For compound 3 the middle estimate is 2.1-fold (0.32 log units) below the measured one, and the stated range covers the measured number.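

No step can be read from compound 1 to compound 3, since compound 1 stands at a limit: the limit of < 1000 nM in this assay, at which 2 of the 3 values shown sit.

The compounds shown leave open whether chloro in place of hydrogen on an aromatic carbon changes inhibition at all, and in which direction.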